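The source may report more compounds than this note shows. Statements on the series, on what has been measured and on what is new or still open speak of the compounds shown alone.

Of the compounds shown here, three have been measured for how they partition between an oily and a watery phase. Compound 1 `CNC(=O)c1cc(C(=O)NCCCC2CNCCO2)cn(Cc2ccccc2)c1=O` gives 1.4 in a physicochemical assay for lipophilicity, at pH 7.4; a lower number here means a more polar compound, a higher number a more lipophilic compound. Compound 2 `CNC(=O)c1cc(C(=O)NC2CCC2)cn(Cc2cccnc2)c1=O` gives 1.8 in this assay. Compound 3 `CNC(=O)c1cc(C(=O)NC2CC2)cn(Cc2cccc3cc[nH]c23)c1=O` gives 3.7 in this assay, the highest of the three numbers: compound 2 is the nearest to it, sitting a full step below it that clearly exceeds the usual scatter, and compound 1 is the furthest, lying even lower, again well beyond the scatter.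

The step now followed goes from compound 3 to compound 4 `CNC(=O)c1cc(C(=O)NC2CC2)cn(Cc2ccc(C)cc2)c1=O`, which has not yet been measured in this assay. The change is confined to the group on a saturated chain carbon bound to an aromatic nitrogen: 4-methylphenyl in place of 1H-indol-7-yl on a saturated chain carbon bound to an aromatic nitrogen. The 1H-indol-7-yl with its 1 hydrogen-bond donor leaves, and a 4-methylphenyl with 0 hydrogen-bond donors enters; both carry no net charge.

Among the compounds with values here, no pair among the measured compounds differs in only one place, so no single step can be read directly from the numbers. The expectation is therefore cautious: a small rise, or no step beyond the scatter, from compound 3 to compound 4 is expected, as a number 0.10 log units higher from compound 3 to compound 4 (within the scatter). Compound 4 is thus estimated to give 3.8 in this assay, expected to fall between 3.2 and 4.4, because compound 3 already stands at 3.7.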

Compound 4, distribution coefficient: 3.5
Estimate against measurement, compound 4: 0.30 log units above; the range from low to high includes it.
By their numbers in this assay, from the lowest: compound 1; then compound 2; then compounds 4 and 3 (each within the scatter of the next).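

In this assay, within the data shown here, the change on a saturated chain carbon bound to an aromatic nitrogen gives the first step that can be read in a single place: a number 0.20 log units lower from compound 3 to compound 4 (within the scatter), on replacing 1H-indol-7-yl with 4-methylphenyl. In this one pair, then, a group with two aromatic rings and a hydrogen-bond donor gives way to a smaller group with one aromatic ring and no hydrogen-bond donor, and the two compounds cannot be told apart by this measurement. No supporting measurement is available to explain this result.

Among these compounds, compound 1 and compound 2 each differ from compound 3 and compound 4 in more than one place, so no steps involving them can be read, and this single pair cannot show whether the same result would hold with a different amide group elsewhere on the shared core. It also leaves open how this assay would respond to a more sharply different group at this position, such as a phenyl ring carrying a carboxylic acid or an amine.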